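This account rests on a few compounds, and the source may have more. Where it says the series, first, only, none or still open, it means among the compounds named here.

Measured so far:
Compound 1 `COc1ccc(N)cc1CS(=O)(=O)/C=C/c1c(OC)cccc1OC` gives 25000 nM in a functional assay on K562 cells (Homo sapiens) for cytotoxicity, read by trypan blue exclusion, with a stated time of 96 h; a lower number here means a stronger inhibitor, a higher number a weaker inhibitor.
Compound 2 `COC(=O)C(C)(C)Nc1cc(CS(=O)(=O)/C=C/c2c(OC)cc(OC)cc2OC)ccc1OC` gives 800 nM in this assay.

Of these two numbers, compound 2 has the lower one, and its gap to compound 1 lies beyond the usual scatter, so compound 2 is the stronger inhibitor of the pair. Compound 3 `COc1ccc(C(Nc2cc(CS(=O)(=O)/C=C/c3c(OC)cc(OC)cc3OC)ccc2OC)C(=O)O)cc1` has not yet been measured. It differs from compound 2 in a single place: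

carboxy(4-methoxyphenyl)methyl in place of 1-(methoxycarbonyl)-1-methylethyl on a nitrogen on an aromatic ring

The size of this step cannot be read from the two measured compounds, which differ from each other in more than one place, so no single change with a known effect is available to lean on. A moderate weakening, within a wide band of uncertainty, is expected; the estimated step is a 1.9-fold higher number from compound 2 to compound 3 (0.27 log units; within the scatter). Compound 3 is therefore expected to give about 1500 nM in this assay, with a likely range from 300 nM to 8000 nM.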

Compound 3, half-maximal inhibitory concentration: 15 nM
Estimate against measurement, compound 3: 100-fold (2.00 log units) above; measured number below the stated range.
By their numbers in this assay, from the lowest: compound 3; then compound 2; then compound 1.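

For the compounds shown here, the group on a nitrogen on an aromatic ring proves to be a place where the number in this assay can move a long way: carboxy(4-methoxyphenyl)methyl in place of 1-(methoxycarbonyl)-1-methylethyl gives a 53-fold lower number from compound 2 to compound 3 (1.73 log units; beyond the scatter), a large step that the earlier compounds could not isolate. The entering group is larger, adds a six-membered aromatic ring of carbon only and brings a hydrogen-bond donor, so several features change together in this one step. No measurement at hand explains why the number falls so far.

Which part of the new group matters remains open, since this single step cannot separate its pieces. A methyl ester in place of the carboxy group, or a plain phenyl ring in place of the 4-methoxyphenyl, would help to divide the effect.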